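This account rests on a few compounds, and the source may have more. Where it says the series, first, only, none or still open, it means among the compounds named here.

Measured in a functional assay on K562 cells (Homo sapiens) for antiproliferative activity, with a stated time of 72 h; a lower number here means a stronger inhibitor, a higher number a weaker inhibitor:
- compound 1 `OC[C@H]1O[C@@H](n2cnc3c(NCc4ccccc4Cl)ncnc32)[C@H](O)[C@@H]1O`: 64000 nM
- compound 2 `Cc1cccc(CNc2ncnc3c2ncn3[C@@H]2O[C@H](CO)[C@@H](O)[C@H]2O)c1`: > 166000 nM (a limit)
- compound 3 `COc1cccc(CNc2ncnc3c2ncn3[C@@H]2O[C@H](CO)[C@@H](O)[C@H]2O)c1OC`: > 166000 nM (a limit)

Compound 3 gives only a limit in this assay, > 166000 nM. The evidence here is the limit of > 166000 nM in this assay, at which 2 of the 3 values shown sit, so compound 1 is the only one of the three with a number.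

The next compound is compound 4 `OC[C@H]1O[C@@H](n2cnc3c(NCc4ccc(F)cc4Cl)ncnc32)[C@H](O)[C@@H]1O`, which is not yet measured. The change is 2-chloro-4-fluorophenyl in place of 2,3-dimethoxyphenyl, on a saturated chain carbon bound to a nitrogen on an aromatic ring: 2-chloro-4-fluorophenyl in place of 2,3-dimethoxyphenyl on a saturated chain carbon bound to a nitrogen on an aromatic ring.

Among the measured compounds shown here, two measured steps bear on this change. The 2,3-dimethoxyphenyl group in place of 2-chlorophenyl gave an at least 2.5-fold higher number from compound 1 to compound 3 (0.41 log units; beyond the scatter). The 3-methylphenyl group in place of 2-chlorophenyl gave an at least 2.5-fold higher number from compound 1 to compound 2 (0.41 log units; beyond the scatter). The remaining step adds nothing, being a step that the two limits leave unreadable from compound 2 to compound 3.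

Compound 4 carries chlorine on this ring, as compound 1 does at 64000 nM, so the first of these steps is read in reverse, towards a lower number in this assay. For the measured compounds named here, no measured step covers the added fluorine, and a second limit remains possible.

The expected step is an at least 2.3-fold lower number from compound 3 to compound 4 (0.37 log units; beyond the scatter), of modest size.

For compound 4 the estimated value is 70000 nM, with an expected range of 25000 nM to 170000 nM.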

Compound 4, half-maximal inhibitory concentration: 15600 nM
Compound 4: the middle estimate sits 4.5-fold (0.65 log units) above what was measured; the whole stated range lies above it.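

In this assay, among the compounds shown here, fluoro in place of hydrogen on an aromatic carbon gives a 4.1-fold lower number from compound 1 to compound 4 (0.61 log units; beyond the scatter), the first change on this ring to move the number down rather than up. Set against the groups that had given only limits, 2-chloro-4-fluorophenyl gives an at least 10-fold lower number from compound 3 to compound 4 (1.02 log units; beyond the scatter) and an at least 10-fold lower number from compound 2 to compound 4 (1.02 log units; beyond the scatter), and both sizes are minimum sizes, since each starts from a limit and not from a number. Among the four compounds, compound 1 and compound 4 carry chlorine on this ring and give numbers, while compound 2 and compound 3 carry none and remain limits, with no compound going against this split: the limit of > 166000 nM in this assay, at which 2 of the 4 values shown sit.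

The share of the chlorine and of the fluoro in the result stays unresolved, as no phenyl group with fluoro alone appears among these compounds. Also open, going by these compounds, is whether another group in place of fluoro on that ring, such as trifluoromethyl, a nitrile or an amine, would lower the number further or raise it again.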